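The source may hold more compounds than are shown below. What is called first, only, known or untested is meant among the compounds shown, and "the series" means these compounds.

Among the compounds with values here, compound 1 `C=CC[C@H]1C[C@]2([C@@H](C)Cc3ccc(OC)c(C(N)=O)c3)OCOC2=CC1=O` is tested in a functional assay on M14 cells (Homo sapiens) for antiproliferative activity, with a stated time of 72 h (a higher number here means a weaker inhibitor, a lower number a stronger inhibitor), where compound 1 gives 12 nM, the lowest of the two numbers so far. Compound 2 `C=CC[C@H]1C[C@]2(C(C)Cc3ccc(OC)c(OC(C)=O)c3)OCOC2=CC1=O` gives 16 nM in this assay, a value within the scatter of compound 1. Compound 3 `C=CC[C@H]1C[C@]2([C@@H](C)Cc3ccc(OC)c(F)c3)OCOC2=CC1=O` has not yet been measured; it differs from compound 1 by fluoro in place of carbamoyl on an aromatic carbon. Within the data shown here, no measured pair isolates this exchange, so the size of the step is open; a modest rise beyond the scatter, or none at all, seems most likely. For compound 3 the expected value in this assay is 25 nM, with a range from 8 nM to 80 nM, meaning an expected step of a 2.1-fold higher number from compound 1 to compound 3 (0.32 log units; beyond the scatter).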

Compound 3, half-maximal inhibitory concentration: 8 nM
Beside the measured number, compound 3's estimate is 3.1-fold (0.49 log units) above it; the range from low to high includes it.
By their numbers in this assay, from the lowest: compounds 3, 1 and 2 (each within the scatter of the next).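

The step of a 1.5-fold lower number from compound 1 to compound 3 (0.18 log units; within the scatter) in this assay shows that this aromatic carbon, ortho to a methoxy group, accepts fluoro as well as carbamoyl with no change beyond the scatter. For this pair, the hydrogen-bond donor and acceptor counted for carbamoyl are therefore not needed to keep the number low. Nothing available explains why the two groups read alike. As far as these compounds go, whether plain hydrogen, an amine or a carboxylic acid on this carbon would stay within the same range remains open.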